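Removing the methoxy from the phenyl ring of compound 2

A few compounds are considered here, and "the series" means these few. Any claim that something is new, unique, unknown or untested is made for them only; others in the source may bear on it.

Compound 2 `COc1ccc(-c2[nH]c3ccc(OC)cc3c2/C=C(\C#N)S(=O)(=O)c2ccccc2)cc1` gives 1400 nM in a functional assay on MDA-MB-231 cells (Homo sapiens) for inhibition, read by sulforhodamine B assay, with a stated time of 48 h; a lower number here means a stronger inhibitor of growth, a higher number a weaker inhibitor of growth. Among the compounds with values here, this is the highest of the two numbers measured so far; its nearest neighbour is compound 1 `COc1ccc(-c2[nH]c3ccccc3c2/C=C(\C#N)S(=O)(=O)c2ccccc2)cc1`, which in this assay gives 649 nM. Within the data shown here, the one measured step, a 2.2-fold higher number from compound 1 to compound 2 (0.33 log units; beyond the scatter), concerns a methoxy entering the shared core on an aromatic carbon and is modest but beyond the scatter.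

Compound 3 `COc1ccc2[nH]c(-c3ccccc3)c(/C=C(\C#N)S(=O)(=O)c3ccccc3)c2c1` differs from compound 2 by hydrogen in place of methoxy on an aromatic carbon; read one bond further out, a 4-methoxyphenyl becomes a phenyl. Among the measured compounds shown here, no measured pair touches this ring, so the step from compound 1 to compound 2 bears on it only by analogy: a methoxy on another aromatic carbon changed the number in this assay modestly. The direction for the ring of carbon only cannot be read from the data; a step of similar or smaller size, in either direction, is the reasonable expectation. Compound 3 is therefore expected to give about 1200 nM in this assay, with a range of 500 nM to 3000 nM, an expected step of a 1.2-fold lower number from compound 2 to compound 3 (0.07 log units; within the scatter).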

Compound 3, concentration for 50% growth inhibition: 7500 nM
Estimate against measurement, compound 3: 6.3-fold (0.80 log units) below, and the stated range ends below it.
By their numbers in this assay, from the lowest: compound 1; then compound 2; then compound 3.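

The 4-methoxyphenyl of compound 2 is not interchangeable with a plain phenyl in this assay: the change to phenyl gives a 5.4-fold higher number from compound 2 to compound 3 (0.73 log units; beyond the scatter) and places this methoxy, para to a large group, among the features that matter in the series. Within the data shown here, the direction differs from that of the only earlier step, a 2.2-fold higher number from compound 1 to compound 2 (0.33 log units; beyond the scatter), where the number rose as a methoxy entered on another aromatic carbon; here the number rises as a methoxy leaves. Across these three compounds, a methoxy therefore goes with a higher number in one place and a lower number in the other, so the effect of this group cannot be carried from one aromatic carbon to another, and nothing shown gives the reason for this difference.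

The compounds shown do not tell whether this position depends on the whole methoxy or would accept a hydroxy, a fluorine, a chlorine, an amine or a longer ethoxy chain. They also leave open whether the gain from the 4-methoxyphenyl holds when the methoxy on the other aromatic carbon is absent, as the two changes are each read in only one context.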